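The source may report more compounds than this note shows. Statements on the series, on what has been measured and on what is new or still open speak of the compounds shown alone.

Compound 1 `Cc1ccc(CS/C(=C/c2ccc(O)cc2)C(=O)c2ccc(Cl)cc2)cc1`: 10000 nM
Compound 2 `O=C(/C(=C\c1ccc(F)c([N+](=O)[O-])c1)S(=O)(=O)c1ccc(Br)cc1)c1ccc(Br)cc1`: 25000 nM
Compound 3 `Cc1ccc(CS/C(=C/c2ccc(F)c(C)c2)C(=O)c2ccc(Cl)cc2)cc1`: 25000 nM

In a functional assay on DU-145 cells (Homo sapiens) for inhibition, read by trypan blue exclusion, with a stated time of 96 h (on this read-out lower numbers stand for stronger inhibition of growth and higher numbers for weaker inhibition of growth), compound 3 gives 25000 nM, level with compound 2 and, together with it, the highest number of the three. Compound 4 `Cc1ccc(CS/C(=C/c2c(O)cc(O)cc2O)C(=O)c2ccc(Cl)cc2)cc1` differs from compound 3 in one place: 2,4,6-trihydroxyphenyl in place of 4-fluoro-3-methylphenyl on a double-bonded chain carbon bound to a double-bonded chain carbon. Going by the values given here, one measured step bears on this change, a 2.5-fold higher number from compound 1 to compound 3 (0.40 log units; beyond the scatter), a modest rise on losing 4-hydroxyphenyl. Read backwards, this single pair suggests that a hydroxy-bearing ring may bring a modest fall, though no measured compound carries 2,4,6-trihydroxyphenyl. The expected change is a 2.3-fold lower number from compound 3 to compound 4 (0.36 log units; beyond the scatter). For compound 4 the estimated value is 11000 nM, with an expected range of 3500 nM to 30000 nM.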

Compound 4, concentration for 50% growth inhibition: 50000 nM
For compound 4 the middle estimate is 4.5-fold (0.66 log units) below the measured one, and the stated range ends below it.
By their numbers in this assay, from the lowest: compound 1; then compounds 2, 3 and 4 (each within the scatter of the next).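

In this assay, 2,4,6-trihydroxyphenyl in place of 4-fluoro-3-methylphenyl gives a 2.0-fold higher number from compound 3 to compound 4 (0.30 log units; within the scatter), so these two rings cannot be told apart at this position. 2,4,6-trihydroxyphenyl in place of 4-hydroxyphenyl gives a 5.0-fold higher number from compound 1 to compound 4 (0.70 log units; beyond the scatter), so a hydroxy-bearing ring does not by itself give the low number of compound 1. Nothing available explains this difference. On these data alone, it remains open whether a ring carrying an amine or a carboxylic acid at this position would give a lower number than compound 1.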